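Cyclopropyl for methyl on the sulfonamide chain

This account rests on a few compounds, and the source may have more. Where it says the series, first, only, none or still open, it means among the compounds named here.

In an assay on Sf9 cells for inhibition of serine/threonine-protein kinase 4 (Homo sapiens), read by luminescence and ADP-Glo, with a stated time of 1 h, in the presence of a further agent that is not named here (on this read-out higher numbers stand for weaker inhibition and lower numbers for stronger inhibition), compound 3 `CCNS(=O)(=O)c1ccc(Nc2ncc3c(n2)N(C)C(c2ccccc2C)C(=O)N3C)cc1` gives 119 nM, the lowest of the three numbers shown. Compound 2 `CN1C(=O)C(CC2CC2)N(C)c2nc(Nc3ccc(S(N)(=O)=O)cc3)ncc21` lies nearest, giving 211 nM in this assay, a gap within the scatter; compound 1 `CC(C)C1C(=O)N(C)c2cnc(Nc3ccc(S(N)(=O)=O)cc3)nc2N1C` lies furthest, giving 254 nM in this assay, a gap beyond it. Compound 4 `Cc1ccccc1C1C(=O)N(C)c2cnc(Nc3ccc(S(=O)(=O)NCC4CC4)cc3)nc2N1C` has not yet been measured. It differs from compound 3 by cyclopropyl in place of methyl on a saturated chain carbon bound to a sulfonamide nitrogen. Going by the values given here, the one measured step that touches a related change, a cyclopropylmethyl group entering on a saturated ring carbon, is a 1.2-fold lower number from compound 1 to compound 2 (0.08 log units; within the scatter), a small shift that sits within the scatter. The present change sits on a different part of the molecule, so that step bears on it only loosely. On this basis the account expects, for the step from compound 3 to compound 4 in this assay, no shift beyond the scatter, leaning slightly toward a lower number: a 1.2-fold lower number from compound 3 to compound 4 (0.08 log units; within the scatter). For compound 4 in this assay the estimate is therefore 100 nM, with a range from 45 nM to 220 nM.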

Compound 4, half-maximal inhibitory concentration: 60 nM
Compound 4: the middle estimate sits 1.7-fold (0.22 log units) above what was measured; low and high end bracket the measured number.
By their numbers in this assay, from the lowest: compounds 4, 3, 2 and 1 (each within the scatter of the next, the first and the last beyond it).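

The change from methyl to cyclopropyl on a saturated chain carbon bound to a sulfonamide nitrogen, which turns ethylsulfamoyl into (cyclopropylmethyl)sulfamoyl, reads in this assay as a 2.0-fold lower number from compound 3 to compound 4 (0.30 log units; within the scatter). Going by these compounds alone, this is the first measured step at the sulfonamide chain, and it shows that this position accepts a three-membered ring and two further carbons with no rise in the number, although the step does not go beyond the scatter. Nothing shown here gives a reason for this result. From the compounds shown here alone, it remains open how this position would respond to a longer chain such as n-butyl, to a phenyl ring or to a terminal amine on the sulfonamide nitrogen. Going by these compounds, it is also open whether the same change would read alike with isopropyl or cyclopropylmethyl on the saturated ring carbon.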